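This account rests on a few compounds, and the source may have more. Where it says the series, first, only, none or still open, it means among the compounds named here.

Compound 1 `CNc1c(C(=O)c2ccccc2)sc2nc(-c3cccs3)ccc12`: 0.42 ug/mL
Compound 2 `COc1ccc(C(=O)c2sc3nc(-c4cccs4)ccc3c2N)cc1`: 0.77 ug/mL
Compound 3 `COc1ccc(C(=O)c2sc3nc(-c4cccs4)ccc3c2N)c(OC)c1`: 0.52 ug/mL

In a functional assay on WI-38 VA13 cells (Homo sapiens) for cytotoxicity (a lower number here means that less compound is needed, a higher number that more compound is needed for the effect), compound 2 gives 0.77 ug/mL, and its gaps to compound 3 and compound 1 both lie within the scatter, so the three numbers sit together and none stands apart. Compound 4 `CCC(=O)c1sc2nc(-c3cccs3)ccc2c1N` differs from compound 2 by ethyl in place of 4-methoxyphenyl on a carbonyl carbon. For the measured compounds named here, the only measured step, a 1.5-fold lower number from compound 2 to compound 3 (0.17 log units; within the scatter), changes a methoxy on the aromatic ring and leaves the ketone substituent untouched, so no measured step bears directly on the present change. Without a comparable step, no direction beyond the scatter can be predicted with confidence, and the estimate is wide. Compound 4 is expected at about 1.2 ug/mL, with a range of 0.35 ug/mL to 4 ug/mL. This estimate corresponds to a 1.6-fold higher number from compound 2 to compound 4 (0.19 log units; within the scatter).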

Compound 4, half-maximal effective concentration: 0.89 ug/mL
Estimate against measurement, compound 4: 1.3-fold (0.13 log units) above; the range from low to high includes it.
By their numbers in this assay, from the lowest: compounds 1, 3, 2 and 4 (each within the scatter of the next, the first and the last beyond it).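

In this assay, ethyl in place of 4-methoxyphenyl on a carbonyl carbon gives a 1.2-fold higher number from compound 2 to compound 4 (0.06 log units; within the scatter). An aromatic ring at this position is therefore not required for a number in this range: ethyl, with no ring and only 2 heavy atoms, reads the same as the 8-heavy-atom group within the scatter. No measurement shown gives a reason for this result. As far as these compounds go, it remains open whether a longer chain such as hexyl, or a carboxylic acid, would also stay within the scatter of compound 2 on this carbonyl carbon.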